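The source may hold more compounds than are shown below. What is called first, only, known or untested is meant among the compounds shown, and "the series" means these compounds.

In a functional assay on A-375 cells (Homo sapiens) for antiproliferative activity, read by MTT assay, with a stated time of 24 h, tested at 0.01 ug/mL (on this read-out lower numbers stand for a weaker effect and higher numbers for a stronger effect at the one concentration tested), compound 2 `CCc1ccc2nc(C(=O)Nc3c(F)cc(-c4cccc(F)c4)cc3F)c(C)c(C(=O)O)c2c1` gives -0.45%, and compound 1 `Cc1c(C(=O)Nc2c(F)cc(-c3cccc(F)c3)cc2F)nc2ccc(F)cc2c1O` gives -0.35%, so the two numbers lie within the usual scatter of each other and neither compound shows an effect at the concentration tested. Compound 3 `Cc1c(C(=O)Nc2c(F)cc(-c3cccc(F)c3)cc2F)nc2ccc(F)cc2c1C(=O)O` has not yet been measured; it differs from compound 2 in one place: fluoro in place of ethyl on an aromatic carbon. For the measured compounds named here, no step between measured compounds is available to guide this change, and since both measured compounds sit near zero, the expected change is a number 0.5 percentage points higher from compound 2 to compound 3 (within the scatter), none beyond the scatter. Compound 3 is therefore expected to give about 0%, between -8% and 8%.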

Compound 3, a percentage reported as inhibition, at one concentration (the size of the read-out at that concentration, not a potency): -0.56%
Beside the measured number, compound 3's estimate is 0.6 percentage points above it; low and high end bracket the measured number.
By their numbers in this assay, from the lowest: compounds 3, 2 and 1 (each within the scatter of the next).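

In this assay, fluoro in place of ethyl gives a number 0.1 percentage points lower from compound 2 to compound 3 (within the scatter), and carboxy in place of hydroxy gives a number 0.2 percentage points lower from compound 1 to compound 3 (within the scatter). Neither change on these aromatic carbons produces a detectable effect at this one concentration, so the result shows no sign that either group matters here, though a read-out this close to zero can hide differences. No measured data are available to explain this flat result. On these data alone, it remains open whether an amine or a longer chain on the carbon that carries the fluoro in compound 3 would produce an effect. Whether any of these compounds acts at a higher concentration also remains open.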